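The source may report more compounds than this note shows. Statements on the series, on what has been measured and on what is new or still open speak of the compounds shown alone.

Measured so far:
compound 1 `Cn1ncc(Cl)c1-c1cc(C(=O)N[C@@H]2CN[C@H](CCN3CCC(O)CC3)C[C@H]2c2ccc(Cl)c(Cl)c2)oc1Cl` gives 5.99 nM in an assay for inhibition of RAC-alpha serine/threonine-protein kinase (Homo sapiens), read by HTRF, with a stated time of 1 h; a lower number here means a stronger inhibitor, a higher number a weaker inhibitor
compound 2 `Cn1ncc(Cl)c1-c1cc(C(=O)N[C@@H]2CN[C@H](CCO)C[C@H]2c2ccc(F)c(F)c2)oc1Cl` gives 0.98 nM in this assay

Compound 1 holds the higher of the two numbers; compound 2 sits lower by a gap beyond the scatter. Compound 3 `Cn1ncc(Cl)c1-c1cc(C(=O)N[C@@H]2CN[C@H](CCN3CCCCC3)C[C@H]2c2ccc(Cl)c(Cl)c2)oc1Cl` is not yet measured. It departs from compound 1 by hydrogen in place of hydroxy on a saturated ring carbon. Within the data shown here, no measured pair covers this change, so the data give no direction for it. In this assay the expected step is a 1.3-fold higher number from compound 1 to compound 3 (0.13 log units; within the scatter), not beyond the scatter. Compound 3 is estimated at 8 nM, with a range from 3 nM to 20 nM.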

Compound 3, half-maximal inhibitory concentration: 5.65 nM
Estimate against measurement, compound 3: 1.4-fold (0.15 log units) above; the range from low to high includes it.
By their numbers in this assay, from the lowest: compound 2; then compounds 3 and 1 (each within the scatter of the next).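

Hydrogen in place of hydroxy on the 4-hydroxypiperidin-1-yl group gives the first matched step in the series. In this assay it reads as a 1.1-fold lower number from compound 1 to compound 3 (0.03 log units; within the scatter) and so stays within the scatter, which means that at this saturated ring carbon, three ring bonds from the ring nitrogen, the hydroxy is not needed to hold the number. No measured evidence bears on this result.

Still open, on these data alone, is whether a carboxylic acid or a primary amine at this ring carbon would leave the number equally unmoved.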